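A few compounds are considered here, and "the series" means these few. Any claim that something is new, unique, unknown or untested is made for them only; others in the source may bear on it.

Measured compounds in a functional assay (Homo sapiens) for inhibition of Nucleic Acid, tested at 100 uM; a lower number here means less inhibition, a higher number more inhibition at the concentration tested (going by the name of the read-out):
- compound 1 `CN(C)c1nccc2c1ncn2C1O[C@H](CO)[C@@H](O)[C@H]1O`, inhibition 0%
- compound 2 `CCCCCCNc1nccc2c1ncn2C1O[C@H](CO)[C@@H](O)[C@H]1O`, inhibition 8%

Within the data shown here, compound 2 gives the higher of the two numbers, but its only neighbour is compound 1, and the step of a number 8 percentage points higher from compound 1 to compound 2 (within the scatter) is not resolved by this assay. Neither compound shows inhibition of note at the concentration tested.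

Compound 3 `CCNc1nccc2c1ncn2C1O[C@H](CO)[C@@H](O)[C@H]1O` is not yet measured. It differs from compound 2 by hydrogen in place of butyl on a saturated chain carbon, two bonds along the chain from a nitrogen on an aromatic ring. Among the measured compounds shown here, the one measured step that bears on this change is the exchange of dimethylamino for hexylamino, a number 8 percentage points higher from compound 1 to compound 2 (within the scatter), where a much larger change in the chain on the ring nitrogen left the read-out within the scatter. Shortening the hexyl to ethyl is a smaller move within the same family of changes, so no step beyond the scatter is expected in this assay: the estimated step is a number 5 percentage points lower from compound 2 to compound 3 (within the scatter).

Compound 3 is therefore expected to give about 3% in this assay, with a range from -6% to 12%.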

Compound 3, a percentage reported as inhibition, at one concentration (the size of the read-out at that concentration, not a potency): 4%
Compound 3: middle estimate off by 1 percentage points, on the low side; the measured number falls inside the stated range.
By their numbers in this assay, from the lowest: compounds 1, 3 and 2 (each within the scatter of the next).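

In this assay, ethylamino in place of hexylamino gives a number 4 percentage points lower from compound 2 to compound 3 (within the scatter) and so does not separate the two chain lengths, even with a butyl lost from the saturated chain. Ethylamino in place of dimethylamino gives a number 4 percentage points higher from compound 1 to compound 3 (within the scatter), so one ethyl group on that nitrogen is not told apart from two methyl groups either. The earlier pair left a single unresolved exchange, whereas the three amino groups now all lie within the scatter of one another, and no trend with chain length can be claimed at this position.

No independent data bear on why the read-out stays flat across these three compounds.

Still open, going by these compounds, is whether any group at this position can lift inhibition beyond the scatter, for example a benzylamino group, a chain ending in a carboxylic acid or a much longer chain such as dodecylamino. Also open is whether the shared core can show inhibition of note with an unsubstituted amino group in the same place, since the three alkylated amines shown give no clear reference point for that comparison.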